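Capping the free hydroxyl of compound 2

A few compounds are considered here, and "the series" means these few. Any claim that something is new, unique, unknown or untested is made for them only; others in the source may bear on it.

In an ADME assay on HEp-2 cells (Homo sapiens) for cytotoxicity, read by MTT assay, with a stated time of 72 h (a higher number here means a weaker inhibitor, a lower number a stronger inhibitor), compound 2 (`COc1ccc(C2=C(c3cc(OC)c(OC)c(OC)c3)C(=O)C(O)C2)cc1`) gives < 1 ug/mL, which is a limit and not a number. That places it at the limit of < 1 ug/mL in this assay, at which 1 of the 2 values shown sits.

Compound 1 (`COc1ccc(C2=C(c3cc(OC)c(OC)c(OC)c3)C(=O)C(OC(C)=O)C2)cc1`) gives 18 ug/mL in this assay. Among the measured compounds shown here, the only measured step is an at least 18-fold lower number from compound 1 to compound 2 (1.25 log units; beyond the scatter), with hydrogen in place of acetyl on an oxygen on a saturated carbon.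

Compound 3 (`COc1ccc(C2=C(c3cc(OC)c(OC)c(OC)c3)C(=O)C(O[SiH2]C(C)(C)C)C2)cc1`) differs from compound 2 by a group of 5 heavy atoms (4 carbon, 1 silicon; no ring) in place of a hydrogen atom, on an oxygen on a saturated carbon. Its oxygen is therefore capped, as in compound 1, though by a different group. A large move to a higher number in this assay is expected because of an at least 18-fold lower number from compound 1 to compound 2 (1.25 log units; beyond the scatter), read in reverse. For the measured compounds named here, this single pair is the only guide, and the starting point is a limit.

The expected change is an at least 5.0-fold higher number from compound 2 to compound 3 (0.69 log units; beyond the scatter).

For compound 3 the estimate is 5 ug/mL, with an expected range of 1 ug/mL to 25 ug/mL.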

Compound 3, half-maximal inhibitory concentration: 16 ug/mL
For compound 3 the middle estimate is 3.2-fold (0.51 log units) below the measured one; low and high end bracket the measured number.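

Compound 3 shows that the large step seen with the acetyl cap is not unique to that group: on this oxygen on a saturated carbon, the group of 5 heavy atoms (4 carbon, 1 silicon; no ring) gives an at least 16-fold higher number from compound 2 to compound 3 (1.20 log units; beyond the scatter) in this assay. As far as these compounds go, the value of compound 2 is a limit and not a number, so the true size of this step remains unknown: the limit of < 1 ug/mL in this assay, at which 1 of the 3 values shown sits. The two capped compounds cannot be told apart, with a 1.1-fold lower number from compound 1 to compound 3 (0.05 log units; within the scatter), so in this small set compound 2, with its free hydroxyl, stands alone and the two caps read alike.

From the compounds shown here alone, how far the number for compound 2 lies under its limit stays open. So does whether a hydroxyl is needed here, or an amine or a methyl ether on the same carbon would read like compound 2 or like the capped compounds.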